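Quinolinyl amidine at the end of a pyrrole amide chain

This account rests on a few compounds, and the source may have more. Where it says the series, first, only, none or still open, it means among the compounds named here.

Compound 1 `CC(C)CCc1sc(NC(=O)c2cc(NC(=O)c3cc(NC(=N)c4ccc(Cl)cc4)cn3C)cn2C)nc1C(=O)NCCCN(C)C` was tested in an ADME assay on HEK293 cells (Homo sapiens) for cytotoxicity, read by fluorescence and resazurin assay, with a stated time of 20 h (a lower number here means that less compound is tolerated, a higher number that more compound is tolerated), where compound 1 gives 10 ug/mL. Compound 2 `CN(C)CCCNC(=O)c1cc(NC(=O)c2cc(NC(=O)c3cc(NC(=N)c4ccccc4)cn3C)cn2C)cn1C` carries the same amide-linked chain but a phenyl on the carbon with a double bond to nitrogen; in this assay compound 2 returned no result, recorded as "not determined" (no result reported). Compound 3 `CC(C)CCn1cc(NC(=O)c2cc(NC(=O)c3cc(NC(=N)c4ccccc4)cn3C)cn2C)cc1C(=O)NCCCN(C)C` was likewise left without a number, its entry in this assay reading "not determined" (no result reported). On the numbers shown, compound 2 therefore stands without a single value of its own, and one further compound is in the same position, so only compound 1 offers a measured anchor.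

Compound 4 `CN(C)CCCNC(=O)c1cc(NC(=O)c2cc(NC(=O)c3cc(NC(=N)c4cnc5ccccc5c4)cn3C)cn2C)cn1C` differs from compound 2 in one place: quinolin-3-yl in place of phenyl on a carbon with a double bond to nitrogen. Among the compounds with values here, no measured pair in this set isolates that exchange, so the size of the step from compound 2 to compound 4 in this assay cannot be read from data; with compound 2 itself unmeasured, the expectation rests on compound 1 alone, whose 10 ug/mL sets the scale, and no direction beyond the scatter can be claimed. Compound 4 is expected to give about 15 ug/mL in this assay, with a range from 5 ug/mL to 50 ug/mL.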

Compound 4, half-maximal cytotoxic concentration: > 32 ug/mL
Compound 4 ended at the assay's limit (the forecaster's own chance of this, stated with the estimate: 30%); at least 2.1-fold (0.32 log units) between middle value and limit.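

In this assay, compound 4 gives > 32 ug/mL, which is a limit of the assay and not a number. No step can be read between compound 2 and compound 4. The compounds shown leave open how quinolin-3-yl compares with phenyl in this assay, and where the value of compound 4 itself would lie.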